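The source may report more compounds than this note shows. Statements on the series, on what has been measured and on what is new or still open speak of the compounds shown alone.

The set holds three measured compounds, each carrying the same side chain and read in an ADME assay on microsomes from liver (Homo sapiens) for metabolic stability, read by LC-MS, using NADPH, with stated times of 5 min and 30 min, tested at 1 uM; a higher number here means faster removal of the compound, a lower number slower removal. Compound 1 `Cn1cc(-c2cnc(NCc3c(F)ccc4c3CCO4)c3cn[nH]c(=O)c23)cn1` gives 21 mL.min-1.g-1 there. Compound 2 `O=C1c2ccccc2CN1c1cnc(NCc2c(F)ccc3c2CCO3)n2cnnc12` gives 13 mL.min-1.g-1, and compound 3 `Fc1ccc2c(c1CNc1ncc(Oc3ccccc3)c3nncn13)CCO2` gives 18 mL.min-1.g-1. On these numbers compound 1 holds the highest of the three, yet its gaps to compound 3 and to compound 2 both lie within the scatter, so nothing separates the three. For the measured compounds named here, the one measured step that changes a single group, a 1.4-fold higher number from compound 2 to compound 3 (0.14 log units; within the scatter), also stays within the scatter.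

Compound 4 `CNC(=O)c1ncc(-c2cnc(NCc3c(F)ccc4c3CCO4)c3cn[nH]c(=O)c23)n1C` differs from compound 1 by 1-methyl-2-(methylcarbamoyl)-1H-imidazol-5-yl in place of 1-methyl-1H-pyrazol-4-yl on an aromatic carbon. Going by the values given here, the measured step concerns a different core and a different place, and it does not bear on this exchange directly; it shows only that a swap of a group on that core left the reading within the scatter. Among the compounds with values here, with no step that addresses the entering 1-methyl-2-(methylcarbamoyl)-1H-imidazol-5-yl group, the expectation is that compound 4 stays near compound 1, with the step of a 1.2-fold lower number from compound 1 to compound 4 (0.07 log units; within the scatter) expected to fall within the scatter. Compound 4 is therefore estimated at 18 mL.min-1.g-1, with a range from 8 mL.min-1.g-1 to 40 mL.min-1.g-1.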

Compound 4, intrinsic clearance in microsomes: 24 mL.min-1.g-1
Estimate against measurement, compound 4: 1.3-fold (0.12 log units) below; measured number inside the range.
By their numbers in this assay, from the lowest: compounds 2, 3, 1 and 4 (each within the scatter of the next).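

In this assay, for the compounds shown here, the exchange of 1-methyl-1H-pyrazol-4-yl for 1-methyl-2-(methylcarbamoyl)-1H-imidazol-5-yl on the aromatic carbon of the core of compound 1 comes out as a 1.1-fold higher number from compound 1 to compound 4 (0.06 log units; within the scatter) and is the first step in the set read at this place on this core. It shows that an entering group of 10 heavy atoms with 1 hydrogen-bond donor, in place of 1-methyl-1H-pyrazol-4-yl with 0 hydrogen-bond donors, leaves the number within the scatter at this position, so this position tolerates a clear gain in size with no readable shift in removal. Nothing available here accounts for this outcome.

The compounds shown leave open how much of this result belongs to the change of ring and how much to the methylcarbamoyl group, which a plain 1-methyl-1H-imidazol-5-yl group at the same place would separate. They also leave open whether a carboxylic acid or an aminomethyl group in place of the methylcarbamoyl group would keep the number within the scatter of compound 1.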